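Moving the fluorine on the phenyl group

The compounds below may be only part of what the source reports. "The series", "measured", "known", "first", "only" and "open" are said of these compounds alone.

Measured in a functional assay on B16 cells (Mus musculus) for cytotoxicity, read by CCK-8 assay, with a stated time of 24 h; on this read-out higher numbers stand for weaker inhibition and lower numbers for stronger inhibition:
Compound 1 `COc1cccc(-c2nc(N)c(Oc3ccccc3OC)c(Cl)n2)c1` gives 23600 nM
Compound 2 `COc1ccc(-c2nc(N)c(Oc3ccccc3OC)c(Cl)n2)cc1` gives 47800 nM
Compound 3 `COc1ccccc1Oc1c(N)nc(-c2ccccc2F)nc1Cl` gives 13800 nM

Compound 3, at 13800 nM, stands level with compound 1 within the scatter, as a 1.7-fold lower number from compound 1 to compound 3 (0.23 log units; within the scatter) shows. It lies clearly apart from compound 2, with a 3.5-fold lower number from compound 2 to compound 3 (0.54 log units; beyond the scatter). Compound 4 `COc1ccccc1Oc1c(N)nc(-c2cccc(F)c2)nc1Cl` differs from compound 3 in one place, with 3-fluorophenyl in place of 2-fluorophenyl on an aromatic carbon. Going by the values given here, no measured pair moves the fluorine itself. The nearest guide is compound 1 and compound 2, which carry the same methoxy group at different places on the phenyl, and that change gave only a modest 2.0-fold higher number from compound 1 to compound 2 (0.31 log units; beyond the scatter). The other change of group and place, a 1.7-fold lower number from compound 1 to compound 3 (0.23 log units; within the scatter), stayed within the scatter. A small rise at most is therefore expected in this assay, probably none beyond the scatter. The expected step is a 1.3-fold higher number from compound 3 to compound 4 (0.12 log units; within the scatter). For compound 4 the estimated value is 18000 nM, with an expected range from 8000 nM to 40000 nM.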

Compound 4, half-maximal inhibitory concentration: 21700 nM
Beside the measured number, compound 4's estimate is 1.2-fold (0.08 log units) below it; the range from low to high includes it.
By their numbers in this assay, from the lowest: compounds 3, 4 and 1 (each within the scatter of the next); then compound 2.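

In this assay, moving the fluorine from 2-fluorophenyl to 3-fluorophenyl gives a 1.6-fold higher number from compound 3 to compound 4 (0.20 log units; within the scatter), so this first direct test of the move shows that the number does not separate these two placements. Fluoro in place of methoxy also leaves the reading level, with a 1.1-fold lower number from compound 1 to compound 4 (0.04 log units; within the scatter), while 3-fluorophenyl in place of 4-methoxyphenyl gives a modest step beyond the scatter, a 2.2-fold lower number from compound 2 to compound 4 (0.34 log units; beyond the scatter). Nothing at hand accounts for the size of these steps.

The compounds shown leave open whether a 4-fluorophenyl group would read level with the two fluorinated compounds or closer to compound 2 at 47800 nM, which would show whether that place or the methoxy group goes with the weaker reading. They also leave open how a phenyl group carrying a carboxylic acid or an aminomethyl group would read here.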